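Anilinoquinazoline sulfonamides: trifluoromethyl to methyl swap

A few compounds are considered here, and "the series" means these few. Any claim that something is new, unique, unknown or untested is made for them only; others in the source may bear on it.

Measured so far:
- compound 1, `COc1cc2ncnc(Nc3cccc(Br)c3)c2cc1OCCCCC(=O)Nc1ccc(S(N)(=O)=O)cc1`: 11400 nM
- compound 2, `COc1ccc(Nc2ncnc3cc(OC)c(OCCCCC(=O)Nc4ccc(S(N)(=O)=O)cc4)cc23)cc1`: 30200 nM
- compound 3, `NS(=O)(=O)c1ccc(NC(=S)Nc2ccc3ncnc(Nc4cccc(C(F)(F)F)c4)c3c2)cc1`: 7590 nM

In a functional assay on NCI-H1975 cells (Homo sapiens) for antiproliferative activity, read by MTT assay, with a stated time of 72 h (on this read-out higher numbers stand for weaker inhibition and lower numbers for stronger inhibition), compound 3 gives the lowest of the three numbers. Its gap to compound 1 lies within the scatter, so no order between those two can be claimed; its gap to compound 2 lies beyond the scatter.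

Compound 4, `Cc1cccc(Nc2ncnc3ccc(NC(=S)Nc4ccc(S(N)(=O)=O)cc4)cc23)c1`, differs from compound 3 by methyl in place of trifluoromethyl on an aromatic carbon. Within the data shown here, no measured pair shows this change. Among the measured compounds shown here, the only measured step, a 2.6-fold higher number from compound 1 to compound 2 (0.42 log units; beyond the scatter), concerns a different substituent on the same kind of anilino ring and is modest in size; it hints that changes on this ring can shift the number, but it does not tell the direction for a methyl in place of a trifluoromethyl.

For the measured compounds named here, with no direct precedent, the expected step of a 1.3-fold higher number from compound 3 to compound 4 (0.10 log units; within the scatter) is small, and a number within the scatter of compound 3 is the most likely outcome. Compound 4 is therefore estimated at 9500 nM in this assay, with a range from 3000 nM to 30000 nM.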

Compound 4, half-maximal inhibitory concentration: 35400 nM
For compound 4 the middle estimate is 3.7-fold (0.57 log units) below the measured one, outside the stated range (above it).
By their numbers in this assay, from the lowest: compounds 3 and 1 (each within the scatter of the next); then compounds 2 and 4 (each within the scatter of the next).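

In this assay, methyl in place of trifluoromethyl on this aromatic carbon gives a 4.7-fold higher number from compound 3 to compound 4 (0.67 log units; beyond the scatter), so the number at this position responds to the change and 3-methylphenyl does not hold up as a match for 3-(trifluoromethyl)phenyl on this core. The shift points the same way as the earlier step on the anilino ring, a 2.6-fold higher number from compound 1 to compound 2 (0.42 log units; beyond the scatter), although that step involves other substituents on another core, so two steps make no general rule. No measurement at hand bears on why the number moves.

As far as these compounds go, whether a chlorine or a nitrile on this same aromatic carbon would stay within the scatter of compound 3 remains open. Also open, from the compounds shown here alone, is whether the same swap gives a comparable step on the core of compound 1.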